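Isoquinolinyl ether replacing trifluoromethylpyrimidinyl ether on the ketone side chain

A few compounds are considered here, and "the series" means these few. Any claim that something is new, unique, unknown or untested is made for them only; others in the source may bear on it.

The series shares a naphthyloxyacetyl-valine-aspartyl core and differs in the group on the oxygen on the saturated carbon of the ketone side chain. Compound 1 `CCOC(=O)c1c(C)noc1OCC(=O)[C@H](CC(=O)O)NC(=O)[C@@H](NC(=O)COc1cccc2ccccc12)C(C)C` carries a 4-(ethoxycarbonyl)-3-methyl-1,2-oxazol-5-yl group there; in a functional assay on Jurkat cells (Homo sapiens) for inhibition (on this read-out lower numbers stand for stronger inhibition and higher numbers for weaker inhibition), compound 1 gives > 200000 nM, which is a limit of this assay and not a number. Compound 2 `CC(C)[C@H](NC(=O)COc1cccc2ccccc12)C(=O)N[C@@H](CC(=O)O)C(=O)CSC1=NCCS1` carries a thiazoline-thioether in that place; in this assay compound 2 gives > 200000 nM, again only a limit. Among the compounds with values here, compound 3 `CC(C)[C@H](NC(=O)COc1cccc2ccccc12)C(=O)N[C@@H](CC(=O)O)C(=O)COc1ccnc(C(F)(F)F)n1` carries 2-(trifluoromethyl)pyrimidin-4-yl and gives 37000 nM in this assay, the only actual number in the set; the other two values sit at the limit of > 200000 nM in this assay, at which 2 of the 3 values shown sit.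

The two steps that bear on the side-chain group are an at least 5.4-fold lower number from compound 1 to compound 3 (0.73 log units; beyond the scatter) and an at least 5.4-fold lower number from compound 2 to compound 3 (0.73 log units; beyond the scatter), both reading only as lower bounds because the starting values are limits.

Compound 4 `CC(C)[C@H](NC(=O)COc1cccc2ccccc12)C(=O)N[C@@H](CC(=O)O)C(=O)COc1cncc2ccccc12` differs from compound 3 by isoquinolin-4-yl in place of 2-(trifluoromethyl)pyrimidin-4-yl on an oxygen on a saturated carbon. Within the data shown here, no measured step covers an exchange between two aromatic ethers, so the direction is open; the measured steps show only that this position can move the readout by at least a modest amount. The number for compound 4 is therefore expected near that of compound 3, and the estimate is 30000 nM, between 6000 nM and 150000 nM, a step of a 1.2-fold lower number from compound 3 to compound 4 (0.09 log units; within the scatter) that is expected to stay within the scatter.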

Compound 4, half-maximal inhibitory concentration: 166000 nM
Beside the measured number, compound 4's estimate is 5.5-fold (0.74 log units) below it, and the stated range ends below it.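

In this assay, exchanging one aromatic ether for another at the same heavy-atom count is not neutral: a 4.5-fold higher number from compound 3 to compound 4 (0.65 log units; beyond the scatter), so 2-(trifluoromethyl)pyrimidin-4-yl and isoquinolin-4-yl can be told apart on this oxygen. Compound 4 is not clearly separated from the two weakest members, as an at least 1.2-fold lower number from compound 2 to compound 4 (0.08 log units; that floor lies within the scatter) and an at least 1.2-fold lower number from compound 1 to compound 4 (0.08 log units; that floor lies within the scatter) are floors only, and an aromatic ether at this place is thus no guarantee of a number well clear of the assay's ceiling. Compound 3 now has steps beyond the scatter to all three other compounds, while the weak end of the set rests on assay limits and not on numbers: the limit of > 200000 nM in this assay, at which 2 of the 4 values shown sit.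

Going by these compounds, the exchange removes the trifluoromethyl group, changes the hetero atoms of the ring and adds a second aromatic ring all at once, so which of these changes matters stays open; a plain pyrimidin-4-yl ether or a quinolinyl ether would help to separate them. The step between compound 1 and compound 2 cannot be read, and the order at the weak end of the set remains unresolved.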